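Changing the Aryl Group on a Sulfonyl Sulfur

The source may hold more compounds than are shown below. What is called first, only, known or untested is meant among the compounds shown, and "the series" means these compounds.

Of the compounds shown here, three built on one shared core have been measured in a functional assay on PC-3 cells (Homo sapiens) for inhibition; on this read-out lower numbers stand for stronger inhibition and higher numbers for weaker inhibition. Compound 1 `COc1ccc(C(=O)N2CCN(c3nc(N)c4cc(OC)c(OC)cc4n3)CC2)cc1OC` gives 71000 nM, compound 2 `COc1cc2nc(N3CCN(C(=O)c4cccc5ccccc45)CC3)nc(N)c2cc1OC` gives 59000 nM, and compound 3 `COc1cc2nc(N3CCN(S(=O)(=O)c4ccc(Cl)s4)CC3)nc(N)c2cc1OC` gives 25000 nM. Compound 3 therefore carries the lowest of the three numbers; compound 2 is its nearest neighbour and compound 1 its furthest, and both gaps lie beyond the scatter.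

Compound 4 `COc1cc2nc(N3CCN(S(=O)(=O)c4ccc(C(C)(C)C)cc4)CC3)nc(N)c2cc1OC` differs from compound 3 in a single place: 4-(tert-butyl)phenyl in place of 5-chlorothiophen-2-yl on a sulfonyl sulfur. Among the measured compounds shown here, the one measured step between close neighbours, a 1.2-fold lower number from compound 1 to compound 2 (0.08 log units; within the scatter), swapped one aryl group for another on a carbonyl carbon and stayed within the scatter. For the measured compounds named here, no measured step changes an aryl group on a sulfonyl sulfur, so that earlier step is only a loose hint that such a swap may move the number little. Compound 4 is therefore expected to give 25000 nM, with a range from 8000 nM to 80000 nM. Put as a step, the expectation is no change at the digits printed from compound 3 to compound 4 (within the scatter), a change not clearly beyond the scatter.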

Compound 4, half-maximal inhibitory concentration: 4100 nM
Beside the measured number, compound 4's estimate is 6.1-fold (0.79 log units) above it; measured number outside the range, below it.
By their numbers in this assay, from the lowest: compound 4; then compound 3; then compounds 2 and 1 (each within the scatter of the next).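

On a sulfonyl sulfur whose other neighbour is a sulfonamide nitrogen in a ring, the choice of aryl group clearly moves the number in this assay (a 6.1-fold lower number from compound 3 to compound 4 (0.79 log units; beyond the scatter)). Among the compounds shown here, the only earlier aryl swap, made on a carbonyl carbon, stayed within the scatter (a 1.2-fold lower number from compound 1 to compound 2 (0.08 log units; within the scatter)), so this is the first sign that a swap of this kind can shift the read-out, and it gives the lowest number so far. Nothing measured here accounts for the shift.

The swap replaced the ring and its substituent at once, so the compounds shown cannot tell whether the benzene ring, the tert-butyl group or the loss of chlorine matters. Plain phenyl and 4-chlorophenyl on the same sulfur would help separate these, while an amine or a carboxylic acid on the ring remains open too.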